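Swapping a methyl for a fluoro on the sulfonamide ring

The source may report more compounds than this note shows. Statements on the series, on what has been measured and on what is new or still open speak of the compounds shown alone.

In an assay on cells for inhibition of HSP60/HSP10 (Homo sapiens), with a stated time of 60 min (a higher number here means a weaker inhibitor, a lower number a stronger inhibitor), three compounds have been measured so far. Compound 1, `CS(=O)(=O)Nc1ccc(-c2nc3cc(NS(=O)(=O)c4ccc(Cl)s4)ccc3o2)cc1`, gives 43000 nM. Compound 2, `Cc1cccc(S(=O)(=O)Nc2ccc(-c3nc4ccccc4o3)cc2)c1`, reaches only the limit of the assay, > 100000 nM, so no number is known for it. Compound 3, `Cc1cccc(S(=O)(=O)Nc2ccc3oc(-c4ccccc4)nc3c2)c1`, likewise reaches only the limit, > 100000 nM, and so stands at the weak end of what has been seen; (the limit of > 100000 nM in this assay, at which 2 of the 3 values shown sit).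

The next compound, compound 4, is `O=S(=O)(Nc1ccc2oc(-c3ccccc3)nc2c1)c1cccc(F)c1`. It differs from compound 3 in one place: fluoro in place of methyl on an aromatic carbon. The exchange of 3-methylphenyl for 3-fluorophenyl keeps the rest of the molecule, including the shared core, unchanged. No measured pair with this exchange is available, so nothing shown gives the size of such a step. With compound 3 sitting at the limit > 100000 nM, the most that can be expected is a step from compound 3 to compound 4 of a number no higher from compound 3 to compound 4 (the limit leaves the size open), which is no more than the scatter. Compound 4 is therefore estimated at 100000 nM, within a range from 30000 nM to 300000 nM, and it may well again return only a limit.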

Compound 4, half-maximal inhibitory concentration: > 100000 nM
Compound 4 gave a limit, no number (the forecaster's own chance of this, stated with the estimate: 70%); the middle value lies on the limit itself.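

Compound 3 and compound 4 each return only a limit in this assay, not a number, so the step between them cannot be read: the limit of > 100000 nM in this assay, at which 3 of the 4 values shown sit.

The compounds shown leave open how strongly either compound inhibits, and whether fluoro in place of methyl changes that at all.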